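Bromo to formyl on the fused core: second pair

The compounds below may be only part of what the source reports. "The series", "measured", "known", "first", "only" and "open" are said of these compounds alone.

Measured so far in a functional assay on L1210 cells (Mus musculus) for cytotoxicity, with a stated time of 48 h; on this read-out lower numbers stand for stronger inhibition and higher numbers for weaker inhibition:
- compound 1 `O=[N+]([O-])c1ccc(-c2nc3sc(Cc4ccc(Cl)cc4)nn3c2Br)cc1`: 94000 nM
- compound 2 `O=c1oc2ccccc2cc1-c1nc2sc(Cc3ccc(Cl)cc3)nn2c1Br`: 5200 nM
- compound 3 `O=Cc1c(-c2ccc([N+](=O)[O-])cc2)nc2sc(Cc3ccc(Cl)cc3)nn12`: 15000 nM

Compound 1 and compound 3 share a core; compound 3 carries formyl in place of bromo on an aromatic carbon, and in this assay that gave a 6.3-fold lower number from compound 1 to compound 3 (0.80 log units; beyond the scatter). Compound 2 differs from compound 1 in the group on the shared core; how the two cores differ is not broken down here. Among the three measured compounds, compound 2 gives the lowest number in this assay, and its gaps to compound 3 and to compound 1 are both beyond the scatter.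

Compound 4 `O=Cc1c(-c2cc3ccccc3oc2=O)nc2sc(Cc3ccc(Cl)cc3)nn12` is not yet measured. It stands to compound 2 as compound 3 stands to compound 1: formyl in place of bromo on an aromatic carbon. The two places are described almost alike; in compound 1 the change sits next to the ring atom that bears a group of 9 heavy atoms, in compound 2 next to the ring atom that bears a large group, so the change is the same kind of change rather than the same one. For the measured compounds named here, the expectation for compound 4 in this assay rests on the single earlier pair, where the step was a 6.3-fold lower number from compound 1 to compound 3 (0.80 log units; beyond the scatter); with one example only, a somewhat smaller step is assumed, and compound 4 is estimated at 1000 nM, with a range from 300 nM to 3500 nM. The step from compound 2 that this estimate means is expected to be a 5.2-fold lower number from compound 2 to compound 4 (0.72 log units; beyond the scatter).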

Compound 4, half-maximal inhibitory concentration: 890 nM
Estimate against measurement, compound 4: 1.1-fold (0.05 log units) above, and the stated range covers the measured number.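

In this assay, formyl in place of bromo on an aromatic carbon gives a 5.8-fold lower number from compound 2 to compound 4 (0.77 log units; beyond the scatter), so the second pair also moves in the direction of lower numbers. Set beside the first pair, the size of the step carries over from one core to the other, and neither pair in this small set goes against that: the same change on two cores in this assay, a 6.3-fold lower number (0.80 log units; beyond the scatter) from compound 1 to compound 3 and a 5.8-fold lower number (0.77 log units; beyond the scatter) from compound 2 to compound 4, 1.1-fold (0.03 log units) apart, within the scatter of two such steps

This agreement rests on two pairs, a single cell line and a single read-out, so it does not show that the step would hold on a further core, and it gives no reason why the formyl compounds give the lower numbers.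

The compounds shown leave open whether the step belongs to the formyl group itself or would also appear with another group on that aromatic carbon, such as hydroxymethyl, a carboxylic acid, a nitrile or an amine. Also open, from the compounds shown here alone, is whether the step survives when the large group on the neighbouring ring atom is replaced by something other than the two groups seen here, for example a simple phenyl or a longer alkyl chain.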